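A few compounds are considered here, and "the series" means these few. Any claim that something is new, unique, unknown or untested is made for them only; others in the source may bear on it.

Measured compounds:
compound 1, `COc1ccc(-c2cc3ccccc3nc2/C=C/C(=O)c2ccc(OC)c(OC)c2)cc1`, 1050 nM
compound 2, `COc1ccc(-c2cc3ccccc3nc2/C=C/C(=O)c2ccc[nH]2)cc1`, > 10000 nM

The account follows the step from compound 2 to compound 3. In a functional assay on NCI-H1299 cells (Homo sapiens) for antiproliferative activity, read by XTT assay, with a stated time of 72 h (on this read-out higher numbers stand for weaker inhibition and lower numbers for stronger inhibition), compound 1 gives 1050 nM. For compound 2 this assay reports only a limit, > 10000 nM, the compound sitting at the limit of > 10000 nM in this assay, at which 1 of the 2 values shown sits. Going by the values given here, compound 2 thus stands at the weak end of what the two numbers show, and the step of an at least 9.5-fold higher number from compound 1 to compound 2 (0.97 log units; beyond the scatter) is the one measured step in the set.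

Compound 3 `COc1ccc(-c2cc3ccccc3nc2/C=C/C(=O)c2cnc(N)nc2C)cc1` differs from compound 2 in one place: 2-amino-4-methylpyrimidin-5-yl in place of 1H-pyrrol-2-yl on a carbonyl carbon. Among the compounds with values here, the only measured step that bears on this change is the one from compound 1 to compound 2, in which a five-membered ring with one hetero atom replaced a six-membered ring on the carbonyl carbon and the number rose by an at least 9.5-fold higher number from compound 1 to compound 2 (0.97 log units; beyond the scatter). Compound 3 returns a six-membered aromatic ring to that carbon, though with two hetero atoms and an amino group rather than two methoxy groups, so part of that loss is expected to be recovered, with wide uncertainty. Compound 3 is therefore estimated at 4000 nM in this assay, within 800 nM to 20000 nM. That estimate corresponds to an expected step of an at least 2.5-fold lower number from compound 2 to compound 3 (0.39 log units; beyond the scatter).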

Compound 3, half-maximal inhibitory concentration: > 10000 nM
Compound 3: only a limit was reported; the forecaster's own chance of this, stated with the estimate: 35%; at least 2.5-fold (0.39 log units) between middle value and limit.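

In this assay compound 3 gives > 10000 nM, and this value is a limit of the assay, not a number. Putting 2-amino-4-methylpyrimidin-5-yl in place of 3,4-dimethoxyphenyl on the carbonyl carbon gives an at least 9.5-fold higher number from compound 1 to compound 3 (0.97 log units; beyond the scatter), so a six-membered aromatic ring at this place is not enough on its own to keep a readable value, something the earlier step to a five-membered ring could not show. The step between compound 2 and compound 3 cannot be read, and the 1H-pyrrol-2-yl and 2-amino-4-methylpyrimidin-5-yl groups stay unranked, with both compounds resting at the same mark: the limit of > 10000 nM in this assay, at which 2 of the 3 values shown sit.

As far as these compounds go, it remains open which part of the 3,4-dimethoxyphenyl group matters, and whether a plain phenyl or a 4-methoxyphenyl group on the carbonyl carbon would give a readable value in this assay. The compounds shown also leave open how far past the limit compound 2 and compound 3 really lie, and whether the two differ at all.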